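Cytotoxicity of a shared core with a varied triazole substituent

The source may hold more compounds than are shown below. What is called first, only, known or untested is meant among the compounds shown, and "the series" means these compounds.

Measured compounds:
compound 1, `CCCCc1cn(C(c2ccccc2)c2cc3cc(Br)ccc3nc2OC)nn1`, -2.87%
compound 2, `COc1nc2ccc(Br)cc2cc1C(c1ccccc1)n1cc(CCO)nn1`, 0.85%

In an ADME assay on HeLa cells (Homo sapiens) for cytotoxicity, read by sulforhodamine B assay, with a stated time of 48 h, tested at 10 uM (a higher number here means more inhibition at the concentration tested (going by the name of the read-out), a lower number less inhibition), compound 1 gives -2.87%, the lower of the two numbers, while compound 2 gives 0.85%. Going by the values given here, the only measured step, a number 3.7 percentage points higher from compound 1 to compound 2 (within the scatter), lies within the scatter, so both compounds show essentially no inhibition at the tested concentration.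

Compound 3, `COc1nc2ccc(Br)cc2cc1C(c1ccccc1)n1cc(-c2ccccc2C(F)(F)F)nn1`, has not been tested. It differs from compound 1 by 2-(trifluoromethyl)phenyl in place of butyl on an aromatic carbon, on an aromatic carbon of a five-membered aromatic ring with 3 nitrogen. Among the compounds with values here, no measured step concerns this part of the structure; the single step from compound 1 to compound 2 changes a different group and was within the scatter. Within the data shown here, with nothing among the measured compounds pointing elsewhere, the estimate for compound 3 is a step of a number 5.9 percentage points higher from compound 1 to compound 3 (within the scatter), no change beyond the scatter. Compound 3 is accordingly expected to give 3%, in a range from -10% to 20%.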

Compound 3, a percentage reported as inhibition, at one concentration (the size of the read-out at that concentration, not a potency): -1.3%
Estimate against measurement, compound 3: 4.3 percentage points above; measured number inside the range.
By their numbers in this assay, from the lowest: compounds 1, 3 and 2 (each within the scatter of the next).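

In this assay, 2-(trifluoromethyl)phenyl in place of butyl gives a number 1.6 percentage points higher from compound 1 to compound 3 (within the scatter) and, in place of 2-hydroxyethyl, gives a number 2.2 percentage points lower from compound 2 to compound 3 (within the scatter) on the same aromatic carbon of the five-membered aromatic ring with 3 nitrogen. Going by these compounds alone, this position had so far carried only chains without a ring, and it now also carries a six-membered aromatic ring of carbon only, with 10 heavy atoms where butyl has 4, without any step beyond the scatter. Nothing available explains why the number stays flat across these changes.

As far as these compounds go, whether an amine or a carboxylic acid on this carbon would move the number beyond the scatter remains open. The three compounds also do not show whether a change elsewhere on the shared core, such as replacing the bromine, would produce inhibition in this cell assay.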